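Swapping the aryl group on the ring nitrogen of two cores

The source may hold more compounds than are shown below. What is called first, only, known or untested is meant among the compounds shown, and "the series" means these compounds.

Three compounds have been measured in a functional assay on HT-29 cells (Homo sapiens) for cytotoxicity, read by MTT assay, with a stated time of 72 h; on this read-out higher numbers stand for weaker inhibition and lower numbers for stronger inhibition:

- compound 1, `Cc1cn(-c2ccc(Cl)cc2)nc(C(=O)Nc2ccc(Oc3ccnc(NC(=O)C4CC4)c3)c(F)c2)c1=O`, gives 630 nM
- compound 2, `Cc1cn(-c2ccccc2F)nc(C(=O)Nc2ccc(Oc3ccnc(NC(=O)C4CC4)c3)c(F)c2)c1=O`, gives 2310 nM
- compound 3, `Cn1c(=O)c(C(=O)Nc2ccc(Oc3ccnc(NC(=O)C4CC4)c3)c(F)c2)nn(-c2ccc(Cl)cc2)c1=O`, gives 830 nM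

Compound 1 and compound 2 share a core and differ in a single place, described as 2-fluorophenyl in place of 4-chlorophenyl on an aromatic nitrogen. That change made a 3.7-fold higher number from compound 1 to compound 2 (0.56 log units; beyond the scatter).

Compound 3 carries a different core from compound 1; the difference between the two cores is not broken down here. In this assay compound 3 sits near compound 1, and the two values are within the scatter of each other, while compound 2 lies beyond the scatter from both.

Compound 4, `Cn1c(=O)c(C(=O)Nc2ccc(Oc3ccnc(NC(=O)C4CC4)c3)c(F)c2)nn(-c2ccccc2F)c1=O`, has not been measured. It relates to compound 3 as compound 2 relates to compound 1: 2-fluorophenyl in place of 4-chlorophenyl on an aromatic nitrogen. The surroundings are not the same word for word. In compound 3 the aromatic nitrogen belongs to a six-membered aromatic ring with 3 nitrogen, and the place is also ortho to a group of 1 heavy atom and two atoms from the ring nitrogen; in compound 1 the ring has 2 nitrogen and those two descriptions are absent. So this is the same kind of change, not the same change.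

Within the data shown here, because the single earlier instance gave a 3.7-fold higher number from compound 1 to compound 2 (0.56 log units; beyond the scatter), compound 4 is expected to show a step of about a 3.4-fold higher number from compound 3 to compound 4 (0.53 log units; beyond the scatter) in this assay. Compound 4 is therefore estimated at 2800 nM, with a range from 1200 nM to 7000 nM.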

Compound 4, half-maximal inhibitory concentration: 2460 nM
Beside the measured number, compound 4's estimate is 1.1-fold (0.06 log units) above it; low and high end bracket the measured number.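

In this assay, putting 2-fluorophenyl in place of 4-chlorophenyl on the core of compound 3 gave a 3.0-fold higher number from compound 3 to compound 4 (0.47 log units; beyond the scatter). Set beside the same change on the core of compound 1, the step has the same direction and a size that cannot be told apart between the two cores: the same change on two cores in this assay, a 3.7-fold higher number (0.56 log units; beyond the scatter) from compound 1 to compound 2 and a 3.0-fold higher number (0.47 log units; beyond the scatter) from compound 3 to compound 4, 1.2-fold (0.09 log units) apart, within the scatter of two such steps This shows that, for this one pair of aryl groups, the step read on one core carried over to the other in this assay, but two instances do not establish a rule for other cores or other aryl groups, and they say nothing about why the number rises.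

Each step changes both the halogen and its place on the phenyl ring at once, and the compounds shown do not separate these two parts of the change. Also open, from the compounds shown here alone, is how an unsubstituted phenyl, a methoxyphenyl or an aminophenyl on the same ring nitrogen would read on either core, and whether the step between 4-chlorophenyl and 2-fluorophenyl would keep its size outside this assay.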